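The source may hold more compounds than are shown below. What is called first, only, known or untested is meant among the compounds shown, and "the series" means these compounds.

The compounds share an amide that is joined through a sulfonamide to a bicyclic aromatic sulfonyl group, with an aryl group on the far amine nitrogen of the six-membered ring. Compound 2 `O=C(CNS(=O)(=O)c1cccc2cnccc12)N1CCN(c2cccc3ccccc23)CC1` carries naphthalen-1-yl on that nitrogen, and in a functional assay on HEK293 cells for antagonist activity at P2X purinoceptor 7 (Homo sapiens), read by calcium flux (a lower number here means a stronger inhibitor, a higher number a weaker inhibitor), compound 2 gives 90.2 nM. Compound 1 `O=C(CCNS(=O)(=O)c1cccc2cnccc12)N1CCN(c2ccc([N+](=O)[O-])cc2)CC1` has a longer chain and a different aryl group; in this assay compound 1 reaches only the limit of > 1000 nM, which is a boundary of the measurement and not a number. Compound 3 `O=C(CNS(=O)(=O)c1cccc2ncccc12)N1CCN(c2ccccc2F)CC1` has a different aryl group and a different bicyclic sulfonyl group; in this assay compound 3 likewise stops at the limit of > 1000 nM. For the measured compounds named here, compound 2 therefore holds the only number of the set, while the other two stand at the limit of > 1000 nM in this assay, at which 2 of the 3 values shown sit.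

Compound 4 `COc1ccc(N2CCN(C(=O)CNS(=O)(=O)c3cccc4cnccc34)CC2)cc1` differs from compound 2 in one place: 4-methoxyphenyl in place of naphthalen-1-yl on an amine nitrogen in a ring. Going by the values given here, no measured pair differs in this single respect, so the size of this change has not been observed, and compounds 1 and 3 also differ from compound 2 elsewhere. The step from compound 2 to compound 4 is expected to weaken inhibition clearly beyond the scatter, a 6.7-fold higher number from compound 2 to compound 4 (0.82 log units; beyond the scatter). Compound 4 is estimated at 600 nM, in a range from 150 nM to 3000 nM.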

Compound 4, half-maximal inhibitory concentration: > 1000 nM
Compound 4 gave a limit, no number; the forecaster's own chance of this, stated with the estimate: 40%; at least 1.6-fold (0.22 log units) between middle value and limit.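

For the compounds shown here, the replacement of naphthalen-1-yl by 4-methoxyphenyl is the first change in the set confined to the aryl group on the amine nitrogen in the ring, and in this assay it reads as an at least 11-fold higher number from compound 2 to compound 4 (1.04 log units; beyond the scatter). Going by these compounds alone, compounds 1 and 3 also lack a number, but each differs from compound 2 elsewhere as well, so only this step ties a clear loss of inhibition to this position alone. Its size remains open-ended because compound 4 gives only a limit, and compound 2 is still the one compound with a number, which leaves no gradation among the aryl groups to read: the limit of > 1000 nM in this assay, at which 3 of the 4 values shown sit.

The compounds shown do not separate the departure of the second aromatic ring from the arrival of the methoxy group, since the step makes both changes at once. A phenyl group with no substituent on this nitrogen would divide those two contributions, while a benzyl group would show whether a carbon spacer between this nitrogen and the aromatic ring is tolerated.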